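This account rests on a few compounds, and the source may have more. Where it says the series, first, only, none or still open, it means among the compounds named here.

Measured so far:
Compound 1, `CCNC(=O)OC[C@H]1O[C@@H](n2cnc3c(N)ncnc32)[C@H](O)[C@@H]1O`, in an assay on COS-7 cells for inhibition of sodium/nucleoside cotransporter 2 (Homo sapiens), read by scintillation counting, in the presence of a further agent that is not named here (on this read-out higher numbers stand for weaker inhibition and lower numbers for stronger inhibition), gives only a limit, > 100000 nM.
Compound 2, `Nc1ncnc2c1ncn2[C@@H]1O[C@H](COC(=O)NCc2ccccc2)[C@@H](O)[C@H]1O`, in this assay gives only a limit, > 100000 nM.
Compound 3, `CCCCCOC(=O)OC[C@H]1O[C@@H](n2cnc3c(N)ncnc32)[C@H](O)[C@@H]1O`, in this assay gives only a limit, > 100000 nM.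

Compound 3 therefore stands at the limit, and all three measured values sit there: the limit of > 100000 nM in this assay, at which 3 of the 3 values shown sit. The three steps among the measured compounds, a step that the two limits leave unreadable from compound 1 to compound 2, a step that the two limits leave unreadable from compound 1 to compound 3 and a step that the two limits leave unreadable from compound 2 to compound 3, are all unreadable for this reason, so no size can be attached to any change of the carbonyl substituent in this series.

Compound 4, `CCOC(=O)OC[C@H]1O[C@@H](n2cnc3c(N)ncnc32)[C@H](O)[C@@H]1O`, differs from compound 3 by hydrogen in place of propyl on a saturated chain carbon, two bonds along the chain from an oxygen next to a carbonyl group. The steps that touch the same region, from compound 1 to compound 3 and from compound 2 to compound 3, also alter the carbonyl substituent, but each is unreadable, so none gives a readable size for shortening the chain. With every measured compound at the limit, the expected step in this assay is a step that the limit leaves unreadable from compound 3 to compound 4, that is, none beyond the scatter, and compound 4 is expected most likely to return a limit as well. The estimate for compound 4 is 150000 nM, with a range from 40000 nM to 500000 nM.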

Compound 4, half-maximal inhibitory concentration: > 100000 nM
Compound 4 was reported as a limit; the forecaster's own chance of this, stated with the estimate: 85%; the middle value is on the limit's open side.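

Going by these compounds alone, compound 4 gives > 100000 nM in this assay, which is a limit, so no step between compound 1, compound 2, compound 3 and compound 4 can be read: the limit of > 100000 nM in this assay, at which 4 of the 4 values shown sit.
The compounds shown leave open which carbonyl substituent on the shared core, if any, would give a value short of that limit.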